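Swapping Phenethyl for 4-Bromophenyl on the Shared Amide

A few compounds are considered here, and "the series" means these few. Any claim that something is new, unique, unknown or untested is made for them only; others in the source may bear on it.

Going by the values given here, compound 2 `O=C(CCc1ccccc1)Nc1c(C(O)(C(F)(F)F)C(F)(F)F)ccc2ccccc12` gives 1750 nM in an assay on LtK cells with ATP-sensitive inward rectifier potassium channel 11 (Homo sapiens) as the target (a higher number here means that more compound is needed for the effect, a lower number that less compound is needed), the highest of the three numbers measured so far. Compound 1 `O=C(CC1CCCC1)Nc1c(C(O)(C(F)(F)F)C(F)(F)F)ccc2ccccc12` gives 81 nM in this assay, and compound 3 `COc1cccc(C(=O)Nc2c(C(O)(C(F)(F)F)C(F)(F)F)ccc3ccccc23)c1` gives 185 nM. The change to compound 4 `O=C(Nc1c(C(O)(C(F)(F)F)C(F)(F)F)ccc2ccccc12)c1ccc(Br)cc1` is 4-bromophenyl in place of phenethyl on a carbonyl carbon. Among the compounds with values here, two measured steps bear on it. The closest is a 9.5-fold lower number from compound 2 to compound 3 (0.98 log units; beyond the scatter), the same kind of move from phenethyl to an aromatic ring placed directly on the carbonyl carbon. The other is a 2.3-fold higher number from compound 1 to compound 3 (0.36 log units; beyond the scatter), a modest rise. On that basis, compound 4 is expected to show a clearly lower number, an 8.8-fold lower number from compound 2 to compound 4 (0.94 log units; beyond the scatter). The estimate for compound 4 is 200 nM, with a likely range from 60 nM to 700 nM.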

Compound 4, half-maximal effective concentration: 47 nM
Estimate against measurement, compound 4: 4.3-fold (0.63 log units) above, and the stated range ends above it.
By their numbers in this assay, from the lowest: compounds 4 and 1 (each within the scatter of the next); then compound 3; then compound 2.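

A ring carrying bromine directly on the carbonyl carbon does far better than the phenethyl chain, with a 37-fold lower number from compound 2 to compound 4 (1.57 log units; beyond the scatter) as the step. What the ring carries also counts: 4-bromophenyl in place of 3-methoxyphenyl gives a 3.9-fold lower number from compound 3 to compound 4 (0.60 log units; beyond the scatter) here, whereas 4-bromophenyl and cyclopentylmethyl cannot be told apart, with a 1.7-fold lower number from compound 1 to compound 4 (0.24 log units; within the scatter) as their step. No measurement shown here explains these differences.

As far as these compounds go, whether the gain comes from the bromine itself or from where it sits stays open, since that step changes both at once. Unsubstituted phenyl and 3-bromophenyl on the carbonyl carbon would separate the two.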